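A Thiazole Ester in Place of an Oxazole Ester

This account rests on a few compounds, and the source may have more. Where it says the series, first, only, none or still open, it means among the compounds named here.

Compound 1 `COC(=O)CCNC(=O)[C@@H]1O[P@@](=O)(OCOC(=O)c2ocnc2C)OCC1(C)C`: 0.52 h
Compound 2 `CC(C)(C)C(=O)OCO[P@@]1(=O)OCC(C)(C)[C@H](C(=O)NCCC(=O)O)O1`: > 1 h
Compound 3 `COC(=O)CCNC(=O)[C@@H]1O[P@](=O)(OCOC(=O)c2ocnc2C)OCC1(C)C`: 0.27 h

In an ADME assay on blood (Homo sapiens) for pharmacokinetics (a higher number here means that the compound lasts longer, a lower number that the compound disappears faster), compound 3 gives 0.27 h, the lowest of the two numbers shown. Its nearest neighbour is compound 1, with a 1.9-fold lower number from compound 1 to compound 3 (0.28 log units; within the scatter); these two are identical in atoms and bonds and differ only in configuration as drawn, so the step rests on (the fact that compounds 1 and 3 differ only in the configuration as drawn). For compound 2 the assay reports only a limit, > 1 h, and no number.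

Compound 4 `COC(=O)CCNC(=O)[C@@H]1O[P@](=O)(OCOC(=O)c2scnc2C(C)(C)C)OCC1(C)C` differs from compound 3 at the ester: 4-(tert-butyl)-1,3-thiazol-5-yl in place of 4-methyl-1,3-oxazol-5-yl on a carbonyl carbon. Within the data shown here, no measured step touches this acyl group; the only step available, from compound 1 to compound 3, changes configuration alone and sits within the scatter. There is therefore no basis for expecting a shift beyond the scatter, and compound 4 is estimated at 0.3 h, between 0.15 h and 0.7 h, meaning an expected 1.1-fold higher number from compound 3 to compound 4 (0.05 log units; within the scatter).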

Compound 4, half-life: 0.44 h
Estimate against measurement, compound 4: 1.5-fold (0.17 log units) below, within the range that was stated.
By their numbers in this assay, from the lowest: compounds 3, 4 and 1 (each within the scatter of the next). At a limit, above all of these: compound 2.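

Among these compounds, this is the first comparison that touches the acyl group on this carbonyl carbon: with the configuration at phosphorus held as in compound 3, 4-(tert-butyl)-1,3-thiazol-5-yl stands in place of 4-methyl-1,3-oxazol-5-yl, and this assay gives a 1.6-fold higher number from compound 3 to compound 4 (0.21 log units; within the scatter). The entering group has more heavy atoms and carries sulfur rather than oxygen in its ring, yet this exchange of one five-membered aromatic ring for another does not separate the two compounds in this read-out. Nothing shown here offers a reason for this result.

The compounds shown leave open whether the thiazole ester would behave alike with the phosphorus configuration of compound 1. They also leave open whether an acyl group carrying an amine, or a plain phenyl ring, would move the half-life beyond the scatter.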